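The source may report more compounds than this note shows. Statements on the series, on what has been measured and on what is new or still open speak of the compounds shown alone.

Compounds measured in a functional assay on HCT-116 cells (Homo sapiens) for cytotoxicity, read by MTT assay, with a stated time of 72 h; on this read-out lower numbers stand for stronger inhibition and higher numbers for weaker inhibition:
- compound 1 `O=C1c2c[n+]([O-])c3ccccc3c2C(=O)c2c1c1ccccc1n2Cc1cn([C@H]2O[C@H](CO)[C@@H](O)[C@H]2O)nn1`: 710 nM
- compound 2 `O=C1c2c[n+]([O-])c3ccccc3c2C(=O)c2c1c1ccccc1n2Cc1cn(C[C@H](O)CO)nn1`: 400 nM

Compound 1 and compound 2 share one core and differ in a single group on an aromatic nitrogen. Their two numbers lie within the usual scatter of each other, so these values set no order between them.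

Compound 3 `CC1(C)OCC(Cn2cc(Cn3c4c(c5ccccc53)C(=O)c3c[n+]([O-])c5ccccc5c3C4=O)nn2)O1` has not yet been measured in this assay. It differs from compound 2 in one place, on a saturated chain carbon bound to an aromatic nitrogen: 2,2-dimethyl-1,3-dioxolan-4-yl in place of 1,2-dihydroxyethyl on a saturated chain carbon bound to an aromatic nitrogen. Cut one bond further out, this reads as (2,2-dimethyl-1,3-dioxolan-4-yl)methyl in place of 2,3-dihydroxypropyl.

Going by the values given here, only one measured step bears on this: a 1.8-fold lower number from compound 1 to compound 2 (0.25 log units; within the scatter). That step is small, but it involves a different exchange of groups, so it is only a loose guide. Among the compounds with values here, no measured pair shows the effect of this particular change. A step within the scatter, in neither direction, is therefore expected.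

The estimated step is no change at the digits printed from compound 2 to compound 3 (within the scatter).

For compound 3, the expected value is 400 nM, with an estimated range from 130 nM to 1200 nM.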

Compound 3, half-maximal inhibitory concentration: 70 nM
Compound 3: the middle estimate sits 5.7-fold (0.76 log units) above what was measured; the whole stated range lies above it.
By their numbers in this assay, from the lowest: compound 3; then compounds 2 and 1 (each within the scatter of the next).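

In this assay, the group on this saturated chain carbon clearly matters: 2,2-dimethyl-1,3-dioxolan-4-yl in place of 1,2-dihydroxyethyl gives a 5.7-fold lower number from compound 2 to compound 3 (0.76 log units; beyond the scatter), whereas the earlier pair showed no order between its two members. The same holds against the other hydroxylated compound, as (2,2-dimethyl-1,3-dioxolan-4-yl)methyl in place of 3,4-dihydroxy-5-(hydroxymethyl)oxolan-2-yl gives a 10-fold lower number from compound 1 to compound 3 (1.01 log units; beyond the scatter), so compound 3 has the strongest inhibition of the three on this read-out. No measurement shown here explains why the number falls.

This single change removes the 2 hydrogen-bond donors, adds a five-membered ring and adds carbon atoms all at once, and it also replaces a defined stereocentre with an undefined one, so the compounds shown cannot say which of these differences matters. An open-chain 2,3-dimethoxypropyl group would keep the chain without the ring, and a 1,3-dioxolan-4-yl group lacking the two methyl groups would keep the ring without them, so either could begin to separate these differences.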